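This account rests on a few compounds, and the source may have more. Where it says the series, first, only, none or still open, it means among the compounds named here.

Three compounds set the frame. Compound 1 `COc1ccc(S(=O)(=O)C2CCC[C@@H]2C(=O)NO)cc1` gives 22 nM in an assay on isolated protein for inhibition of matrix metalloproteinase-9 (Homo sapiens), read by fluorescence, with stated times of 5 min and 30 min; on this read-out lower numbers stand for stronger inhibition and higher numbers for weaker inhibition. Compound 2 `O=C(NO)[C@H]1CCCC1S(=O)(=O)c1ccc(C#Cc2ccccc2)cc1` gives 0.91 nM in this assay, and compound 3 `O=C(Nc1ccc(S(=O)(=O)C2CCC[C@@H]2C(=O)NO)cc1)c1ccccc1` gives 47 nM in this assay. Compound 3 therefore stands highest of the three: against compound 1 the step is a 2.1-fold higher number from compound 1 to compound 3 (0.33 log units; beyond the scatter), and against compound 2 it is a 52-fold higher number from compound 2 to compound 3 (1.71 log units; beyond the scatter), while the remaining step is a 24-fold lower number from compound 1 to compound 2 (1.38 log units; beyond the scatter). Compound 4 `O=C(Nc1ccc(S(=O)(=O)C2CCC[C@@H]2C(=O)NO)cc1)c1ccc([N+](=O)[O-])cc1` differs from compound 3 in one place: nitro in place of hydrogen on an aromatic carbon, which reads phenyl to 4-nitrophenyl. Going by the values given here, none of the measured steps concerns a change on that ring; all three exchange the whole group on the aromatic carbon of the shared core, so they bear on the step to compound 4 only as a sign of how far numbers move in this assay when the outer part of the molecule is altered. Among the compounds with values here, with no direct precedent, the step is expected to be a 1.1-fold higher number from compound 3 to compound 4 (0.03 log units; within the scatter), not beyond the scatter. Compound 4 is thus estimated at 50 nM in this assay, with a range from 15 nM to 160 nM.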

Compound 4, half-maximal inhibitory concentration: 0.122 nM
Beside the measured number, compound 4's estimate is 410-fold (2.61 log units) above it, outside the stated range (below it).
By their numbers in this assay, from the lowest: compound 4; then compound 2; then compound 1; then compound 3.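

In this assay, going by these compounds alone, adding one nitro to the outer ring of the benzamido group gives a 390-fold lower number from compound 3 to compound 4 (2.59 log units; beyond the scatter), so a change on that ring, which the earlier steps left untouched, can move the number strongly. The earlier exchange of whole groups, a 2.1-fold higher number from compound 1 to compound 3 (0.33 log units; beyond the scatter), gave only a modest step and showed nothing about substitution on this ring; the ring of compound 3 now emerges as a sensitive place, at least for nitro. Nothing available here explains why this single change has so large an effect.

The compounds shown leave open whether the step belongs to nitro itself or would also appear with an amine, a carboxylic acid or a nitrile at the same place. They also leave open whether nitro would have a similar effect on another carbon of that ring, or on the outer phenyl of compound 2.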